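This account rests on a few compounds, and the source may have more. Where it says the series, first, only, none or still open, it means among the compounds named here.

Measured compounds:
compound 1 `Nc1ccccc1NC(=O)c1ccc(CSc2ccc(Br)cc2)cc1`: 45.7%
compound 2 `Nc1ccccc1NC(=O)/C=C/c1ccc(CSc2ccc(Cl)cc2)cc1`: 59.6%
compound 3 `Cc1ccc(SCc2ccc(C(=O)Nc3ccccc3N)cc2)cc1`: 78.3%

In a functional assay on A549 cells (Homo sapiens) for inhibition, read by CCK-8 assay, with a stated time of 72 h, tested at 8 uM (a higher number here means more inhibition of growth at the concentration tested, a lower number less inhibition of growth), compound 2 stands second highest of the three: its number lies beyond the scatter above that of compound 1 and beyond the scatter below that of compound 3. For the measured compounds named here, the only single-point step among the measured compounds is a number 32.6 percentage points higher from compound 1 to compound 3 (beyond the scatter), which shows that what sits on the ring attached to the sulfur can move the reading a long way. Compound 4 `Nc1ccccc1NC(=O)/C=C/c1ccc(CSCCc2ccccc2)cc1` differs from compound 2 by a larger change at that same sulfur: phenethyl in place of 4-chlorophenyl on a sulfur. The measured step swaps one small substituent on an aromatic ring; here the whole aromatic ring on the sulfur is exchanged for a phenethyl group, so the step from compound 1 to compound 3 speaks only indirectly to it, and its direction cannot be read from the data shown. The expected result is therefore a step of uncertain sign, a number 4.6 percentage points lower from compound 2 to compound 4 (within the scatter), most likely within the scatter. For compound 4 the estimate in this assay is 55%, expected between 35% and 75%.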

Compound 4, percent growth inhibition at one concentration: 50.3%
For compound 4 the middle estimate is 4.7 percentage points above the measured one, within the range that was stated.
By their numbers in this assay, from the lowest: compounds 1, 4 and 2 (each within the scatter of the next, the first and the last beyond it); then compound 3.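

In this assay the result is a number 9.3 percentage points lower from compound 2 to compound 4 (within the scatter), so on the core of compound 2 the sulfur can carry phenethyl in place of 4-chlorophenyl without the reading leaving the usual scatter. The earlier step changed only one small substituent on the ring, whereas this one shows that a much larger exchange at the same sulfur can produce a smaller shift in the reading. The exchange removes the chlorine and also changes how the ring is joined to the sulfur, and no measurement here bears on what lies behind the result.

A benzyl or phenylpropyl group on the sulfur would show how the reading follows the length of the chain. An aminoethyl or carboxymethyl group there would test whether an aromatic ring on this side is needed at all.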